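A few compounds are considered here, and "the series" means these few. Any claim that something is new, unique, unknown or untested is made for them only; others in the source may bear on it.

Measured so far:
- compound 1 `Cn1cc(-c2nn(Cc3ccc(C(=O)N4CCCCC4)cc3)c(=O)c3ccccc23)cn1`, in a functional assay on HCT-116 cells (Homo sapiens) for antiproliferative activity, read by MTT assay, with a stated time of 72 h; on this read-out lower numbers stand for stronger inhibition and higher numbers for weaker inhibition: 73900 nM
- compound 2 `CN1CCC(NC(=O)c2ccc(Cn3nc(-c4cnn(C)c4)c4ccccc4c3=O)cc2)CC1`, in this assay: 69500 nM
- compound 3 `Cn1cc(-c2nn(Cc3ccc(C(=O)NC4CC4)cc3)c(=O)c3ccccc23)cn1`, in this assay: 20100 nM

Compound 3 holds the lowest number of the three in this assay, and both of its steps stand beyond the scatter: a 3.7-fold lower number from compound 1 to compound 3 (0.57 log units; beyond the scatter) and a 3.5-fold lower number from compound 2 to compound 3 (0.54 log units; beyond the scatter). Compound 1 and compound 2 sit within the scatter of each other, a 1.1-fold lower number from compound 1 to compound 2 (0.03 log units; within the scatter).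

Compound 4 `Cn1cc(-c2nn(Cc3ccc(C(=O)NC4CC(C)(C)N([O])C(C)(C)C4)cc3)c(=O)c3ccccc23)cn1` differs from compound 3 in one place: a group of 11 heavy atoms (9 carbon, 1 nitrogen, 1 oxygen; one six-membered non-aromatic ring with 1 hetero atom) in place of a group of 3 heavy atoms (3 carbon; one three-membered non-aromatic ring of carbon only), on an amide-type nitrogen. The step that bears on it most directly runs in the opposite direction, a 3.5-fold lower number from compound 2 to compound 3 (0.54 log units; beyond the scatter), where a six-membered ring with one hetero atom on the same amide-type nitrogen was replaced by cyclopropyl. The step of a 3.7-fold lower number from compound 1 to compound 3 (0.57 log units; beyond the scatter) points the same way, a modest gain for the small cyclopropyl group. For compound 4 the account therefore expects the number in this assay to rise again by a modest step, a 3.0-fold higher number from compound 3 to compound 4 (0.47 log units; beyond the scatter), back toward where compound 1 and compound 2 stand. The estimate for compound 4 in this assay is 60000 nM, with a range from 20000 nM to 150000 nM.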

Compound 4, half-maximal inhibitory concentration: 50500 nM
For compound 4 the middle estimate is 1.2-fold (0.07 log units) above the measured one; the range from low to high includes it.
By their numbers in this assay, from the lowest: compound 3; then compounds 4, 2 and 1 (each within the scatter of the next).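

In this assay, compound 4 shows that a second, larger six-membered ring group on the amide-type nitrogen also loses much of the cyclopropyl advantage (in numbers, a 2.5-fold higher number from compound 3 to compound 4 (0.40 log units; beyond the scatter)), leaving compound 3 alone at the low end of the four. Compound 4 cannot be told apart from the other two larger amides (a 1.4-fold lower number from compound 2 to compound 4 (0.14 log units; within the scatter); a 1.5-fold lower number from compound 1 to compound 4 (0.17 log units; within the scatter)), so the change of ring group from compound 2 to compound 4, with its added heavy atoms, shifts nothing that this read-out can resolve. Nothing given here explains why the larger groups share this range.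

The compounds shown leave open whether the lower number belongs to small groups in general, such as methyl or cyclobutyl, or to cyclopropyl alone. They also leave open how a short chain ending in a primary amine or a carboxylic acid would fare on the same nitrogen.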